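The source may hold more compounds than are shown below. What is called first, only, known or untested is meant among the compounds shown, and "the series" means these compounds.

Measured compounds:
Compound 1 (`O=C1c2sc(C#Cc3ccccc3)nc2CN1C1CC1`): in an assay on HEK293 cells for positive allosteric modulation of metabotropic glutamate receptor 5 (Homo sapiens), read by FLIPR, with a stated time of 1 h (a higher number here means that more compound is needed for the effect, a lower number that less compound is needed), compound 1 gives > 10000 nM, which is a limit of the assay and not a number.
Compound 2 (`CN1CCc2nc(C#Cc3ccccc3)sc2C1`): in this assay compound 2 gives 34 nM.
Compound 3 (`CCCCN1CCc2nc(C#Cc3ccccc3)sc2C1`): in this assay compound 3 gives 110 nM.

Among the two numbers, compound 3 holds the higher one; the only measured step into it is a 3.2-fold higher number from compound 2 to compound 3 (0.51 log units; beyond the scatter). Among the compounds with values here, compound 1 sits at the limit of > 10000 nM in this assay, at which 1 of the 3 values shown sits, and differs from compound 3 in more than one place, so it yields no single step. The account now turns to compound 4 (`C(#Cc1nc2c(s1)CN(C1CCCCC1)CC2)c1ccccc1`), reached from compound 3 by the change (cyclohexyl in place of butyl on an amine nitrogen in a ring). Within the data shown here, the one step that bears on this change is the one from compound 2 to compound 3, where lengthening the group on that nitrogen from hydrogen to propyl raised the number by a modest amount. The present change again enlarges the group on the same nitrogen, so a further modest rise is expected, a 2.3-fold higher number from compound 3 to compound 4 (0.36 log units; beyond the scatter), though a single step is a thin basis and the outcome could also stay within the scatter. For compound 4 in this assay the estimated value is 250 nM, expected to fall between 80 nM and 800 nM.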

Compound 4, half-maximal effective concentration: > 10000 nM
Compound 4 gave a limit, no number (the forecaster's own chance of this, stated with the estimate: 10%); middle value at least 40-fold (1.60 log units) away from the limit.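

Within the data shown here, on the amine nitrogen in a ring, the earlier compounds showed only a modest change, a 3.2-fold higher number from compound 2 to compound 3 (0.51 log units; beyond the scatter), and compound 4 breaks with that picture: in this assay the swap of butyl for cyclohexyl gives an at least 90-fold higher number from compound 3 to compound 4 (1.95 log units; beyond the scatter), and the comparison with the methyl compound gives an at least 290-fold higher number from compound 2 to compound 4 (2.46 log units; beyond the scatter). Compound 4 stands at a limit of the assay and not at a number: the limit of > 10000 nM in this assay, at which 2 of the 4 values shown sit.

At this position, then, methyl and butyl both give a measured number while cyclohexyl does not, so the response to a larger group on this nitrogen is not a smooth climb but a sharp drop-off somewhere between butyl and cyclohexyl.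

The compounds shown leave open whether the loss goes with the ring or with the carbon count, since cyclohexyl differs from butyl in both; a straight hexyl chain and a cyclobutyl group on the same nitrogen would separate the two. Also open, going by these compounds, is whether a branched group such as isopropyl falls on the side of butyl or on that of cyclohexyl.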